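Swapping a benzyl group for a furan at the limit

The source may report more compounds than this note shows. Statements on the series, on what has been measured and on what is new or still open speak of the compounds shown alone.

In a functional assay on cells (Platelet, Homo sapiens) for inhibition (on this read-out lower numbers stand for stronger inhibition and higher numbers for weaker inhibition), compound 1 (`CCOC(=O)c1ccc(-c2nn(C)c3ccccc23)cc1`) gives > 10000 nM, which is a limit of the assay and not a number. Compound 2 (`CCOC(=O)c1ccc(-c2nn(Cc3cccc(Cl)c3)c3ccccc23)cc1`) gives > 10000 nM, also a limit. Compound 3 (`CCOC(=O)c1ccc(-c2nn(Cc3ccccc3OC)c3ccccc23)cc1`) gives > 10000 nM, again a limit. All three compounds therefore stand together at the limit of > 10000 nM in this assay, at which 3 of the 3 values shown sit.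

The next compound is compound 4 (`CCOC(=O)c1ccc(-c2nn(-c3ccoc3)c3ccccc23)cc1`), where furan-3-yl takes the place of 2-methoxybenzyl on an aromatic nitrogen: furan-3-yl in place of 2-methoxybenzyl on an aromatic nitrogen.

The measured changes to the group on that nitrogen give no size to build on: a step that the two limits leave unreadable from compound 1 to compound 2, a step that the two limits leave unreadable from compound 1 to compound 3 and a step that the two limits leave unreadable from compound 2 to compound 3. None of these compounds has yielded a number, so the data support no direction for the new change. In this assay the expected change is a step that the limit leaves unreadable from compound 3 to compound 4, with no step beyond the scatter foreseen. For compound 4 the estimated value is 15000 nM, with an expected range from 5000 nM to 40000 nM.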

Compound 4, half-maximal inhibitory concentration: > 10000 nM
Compound 4: a limit, no number; the forecaster's own chance of this, stated with the estimate: 85%; the middle value lies beyond the limit too.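

In this assay compound 4 gives a limit and not a number, as do compound 1, compound 2 and compound 3, so no step among these four compounds can be read: the limit of > 10000 nM in this assay, at which 4 of the 4 values shown sit.

The compounds shown leave open whether any group on that aromatic nitrogen alters inhibition, and by how much.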